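The source may hold more compounds than are shown below. What is called first, only, known or untested is meant among the compounds shown, and "the series" means these compounds.

Measured compounds:
- compound 1, `C=CC(=O)Oc1cc(C(F)(F)F)cc(C(F)(F)F)c1`: in an ADME assay for pharmacokinetics, read by LC-MS, in phosphate buffer, with a stated time of 72 h, at pH 7.4, tested at 250 uM (on this read-out lower numbers stand for a shorter-lived compound and higher numbers for a longer-lived compound), compound 1 gives < 0.017 h, a limit of the assay.
- compound 2, `O=C(CBr)c1cc(C(F)(F)F)cc(C(F)(F)F)c1`: in this assay compound 2 gives < 0.017 h, likewise a limit.

Compound 2 therefore sits at the lower limit (the limit of < 0.017 h in this assay, at which 2 of the 2 values shown sit), and nothing in this assay separates it from compound 1: the step that the two limits leave unreadable from compound 1 to compound 2 cannot be read.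

Compound 3, `FC(F)(F)c1cc(C2CO2)cc(C(F)(F)F)c1`, is not yet measured. It differs from compound 2 by oxiran-2-yl in place of (bromomethyl)carbonyl on an aromatic carbon. For the measured compounds named here, no measured step bears on this change; the only step available is unreadable, so no size or direction can be drawn from the numbers. Going by the values given here, the prior expectation for compound 3 is that it comes out above the limit at which compound 2 sits, but this rests on no measured step here. The estimate for compound 3 in this assay is 40 h (range 4 h to 200 h), which would mean an expected step of an at least 2300-fold higher number from compound 2 to compound 3 (3.37 log units; beyond the scatter).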

Compound 3, half-life: > 50 h
Compound 3 was reported as a limit; the forecaster's own chance of this, stated with the estimate: 35%; middle value at least 1.2-fold (0.09 log units) from the limit.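

Compound 3 alone of the three stands at the upper end of this assay, and its value is a limit, not a number: the limit of > 50 h in this assay, at which 1 of the 3 values shown sits.

The group on this aromatic carbon, meta to two trifluoromethyl groups, now has a readable effect on the half-life: oxiran-2-yl in place of (bromomethyl)carbonyl gives an at least 2900-fold higher number from compound 2 to compound 3 (3.46 log units; beyond the scatter), and oxiran-2-yl in place of (vinylcarbonyl)oxy gives an at least 2900-fold higher number from compound 1 to compound 3 (3.46 log units; beyond the scatter). Both steps rest on limits and give only a minimum size, yet they are the only readable ones in the set.

Going by these compounds, the true half-life of compound 3 remains open, and the step between compound 1 and compound 2 cannot be read. Also open, on these data alone, is whether the long half-life is particular to the oxiran-2-yl ring or would carry over to an aziridine ring, an oxetane ring or an open-chain diol at this position.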